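This account rests on a few compounds, and the source may have more. Where it says the series, first, only, none or still open, it means among the compounds named here.

Measured so far in a toxicity assay on HEK-293T cells (Homo sapiens) for cytotoxicity, read by MTT assay, with a stated time of 72 h; a higher number here means a weaker inhibitor, a lower number a stronger inhibitor
compound 1 `O=C(N/N=C/C1=Cc2ccccc2OC1)c1ccco1` gives 47300 nM
compound 2 `O=C(N/N=C/C1=Cc2ccccc2OC1c1ccccc1)c1ccc(Cl)cc1` gives 13200 nM
compound 3 `COc1ccc(C(=O)N/N=C/C2=Cc3ccccc3OC2c2ccccc2)cc1` gives 90700 nM

Compound 3 lies within the scatter of compound 1. For the measured compounds named here, the only measured step is a 6.9-fold higher number from compound 2 to compound 3 (0.84 log units; beyond the scatter) and it is modest, with methoxy in place of chloro on an aromatic carbon. Compound 4 `O=C(N/N=C/C1=Cc2ccccc2OC1c1ccccc1)c1ccco1` carries furan-2-yl in place of 4-methoxyphenyl on a carbonyl carbon and keeps the core of compound 3. Going by the values given here, no measured step covers this exchange directly. Compound 1 carries furan-2-yl on a different core and gives 47300 nM as a rough anchor. In this assay the expected step is modest and downward, namely a 2.3-fold lower number from compound 3 to compound 4 (0.36 log units; beyond the scatter) as a working figure. The estimated value for compound 4 is 40000 nM within an expected range of 13000 nM to 120000 nM in all.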

Compound 4, half-maximal inhibitory concentration: 11900 nM
For compound 4 the middle estimate is 3.4-fold (0.53 log units) above the measured one, outside the stated range (below it).
By their numbers in this assay, from the lowest: compounds 4 and 2 (each within the scatter of the next); then compounds 1 and 3 (each within the scatter of the next).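

In this assay furan-2-yl in place of 4-methoxyphenyl on a carbonyl carbon gives a 7.6-fold lower number from compound 3 to compound 4 (0.88 log units; beyond the scatter) while furan-2-yl in place of 4-chlorophenyl gives a 1.1-fold lower number from compound 2 to compound 4 (0.05 log units; within the scatter) so among these three groups on the shared core, only 4-methoxyphenyl stands apart. With furan-2-yl held fixed, phenyl in place of hydrogen on a saturated ring carbon gives a 4.0-fold lower number from compound 1 to compound 4 (0.60 log units; beyond the scatter) and so adds a direct reading of that ring position. No data at hand account for these steps.

Open, on these data alone, is how an amine or a carboxylic acid in place of furan-2-yl on the carbonyl carbon would read. Also open, as far as these compounds go, is whether the phenyl step holds with 4-chlorophenyl or 4-methoxyphenyl on the carbonyl carbon.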